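The compounds below may be only part of what the source reports. "The series", "measured", "known", "first", "only" and "open" are said of these compounds alone.

Compound 3 `COc1ccc(CS(=O)(=O)CC(=O)Nc2ccccc2)cc1[N+](=O)[O-]` is the anchor of this step. In an ADME assay on MRC5 cells (Homo sapiens) for cytotoxicity, read by MTT assay, with a stated time of 72 h (on this read-out lower numbers stand for stronger inhibition of growth and higher numbers for weaker inhibition of growth), compound 3 gives only a limit of the assay, > 30000 nM. Compound 1 `COc1ccc(CS(=O)(=O)CC(=O)Nc2c(C)cc(C)cc2C)cc1[N+](=O)[O-]` gives 28000 nM in this assay. Compound 2 `COc1cc(OC)c(/C=C/[S+]([O-])Cc2ccc(OC)c(N)c2)c(OC)c1` also reaches only a limit of the assay in this assay, > 30000 nM. Among the measured compounds shown here, the single measured step, an at least 1.0-fold higher number from compound 1 to compound 3 (0.02 log units; that floor lies within the scatter), lies within the scatter, and the limit of > 30000 nM in this assay, at which 2 of the 3 values shown sit, shows where most of these values sit. Compound 4 `COc1ccc(CS(=O)(=O)CC(=O)Nc2ccccc2)cc1N` differs from compound 3 by amino in place of nitro on an aromatic carbon. For the measured compounds named here, no measured step covers this change, so the expected step is a step that the limit leaves unreadable from compound 3 to compound 4, nothing beyond the scatter. The estimate for compound 4 in this assay is 35000 nM, within a range from 15000 nM to 90000 nM, most likely again as a limit rather than a number.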

Compound 4, concentration for 50% growth inhibition: > 30000 nM
Compound 4: a limit, no number; the forecaster's own chance of this, stated with the estimate: 70%; the middle value is on the limit's open side.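

Among the compounds shown here, compound 3 and compound 4 each give only a limit of the assay, and no step between them can be read. The compounds shown leave open whether amino in place of nitro on an aromatic carbon changes growth inhibition at all.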